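Dimethylcarbamoyl in place of 1-hydroxyethyl: an expected step

The compounds below may be only part of what the source reports. "The series", "measured", "known", "first", "only" and "open" are said of these compounds alone.

Compound 1 `CCn1cc(-c2n[nH]c3cc(-c4cc(C(=O)Nc5cccc(C(F)(F)F)c5)ccc4C)ccc23)cn1` gives 2.6 nM in an assay on isolated protein for inhibition of Discoidin domain-containing receptor 2 (Homo sapiens), read by ELISA, with a stated time of 60 min; on this read-out higher numbers stand for weaker inhibition and lower numbers for stronger inhibition.
Compound 2 `CCCn1cc(-c2n[nH]c3cc(-c4cc(C(=O)Nc5cccc(C(F)(F)F)c5)ccc4C)ccc23)cn1` gives 3.2 nM in this assay.
Compound 3 `Cc1ccc(C(=O)Nc2cccc(C(F)(F)F)c2)cc1-c1ccc2c(-c3cnn(CC(C)O)c3)n[nH]c2c1` gives 3.7 nM in this assay.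

Compound 3 holds the highest of the three numbers, yet its separation from the others is within the scatter, so the three compounds stand level. Compound 4 `Cc1ccc(C(=O)Nc2cccc(C(F)(F)F)c2)cc1-c1ccc2c(-c3cnn(CC(=O)N(C)C)c3)n[nH]c2c1` differs from compound 3 by dimethylcarbamoyl in place of 1-hydroxyethyl on a saturated chain carbon bound to an aromatic nitrogen. The steps measured so far all change this same chain on the aromatic nitrogen: a 1.2-fold higher number from compound 1 to compound 2 (0.09 log units; within the scatter), a 1.4-fold higher number from compound 1 to compound 3 (0.15 log units; within the scatter) and a 1.2-fold higher number from compound 2 to compound 3 (0.06 log units; within the scatter), none beyond the scatter. The change to compound 4 is larger in kind, but on this evidence no step beyond the scatter is expected: a 1.2-fold higher number from compound 3 to compound 4 (0.09 log units; within the scatter). Compound 4 is therefore estimated at 4.5 nM, within a range from 1.5 nM to 15 nM.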

Compound 4, half-maximal inhibitory concentration: 2.7 nM
Estimate against measurement, compound 4: 1.7-fold (0.22 log units) above, within the range that was stated.
By their numbers in this assay, from the lowest: compounds 1, 4, 2 and 3 (each within the scatter of the next).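

Placing dimethylcarbamoyl on this saturated chain carbon bound to an aromatic nitrogen, in this assay, gives (a 1.4-fold lower number from compound 3 to compound 4 (0.14 log units; within the scatter)), and the comparisons with the plain alkyl chains read the same (a 1.2-fold lower number from compound 2 to compound 4 (0.07 log units; within the scatter); a 1.0-fold higher number from compound 1 to compound 4 (0.02 log units; within the scatter)). The position therefore takes a larger group, with 5 heavy atoms, a carbonyl and 0 hydrogen-bond donors, with no step beyond the scatter. No measurement here offers an explanation for this. Still open, as far as these compounds go, is whether an amine, a carboxylic acid or a longer chain at this place would also stay level.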